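A few compounds are considered here, and "the series" means these few. Any claim that something is new, unique, unknown or untested is made for them only; others in the source may bear on it.

In an assay on CHO cells for displacement of a labelled ligand from adenosine receptor A1 (Homo sapiens), read by scintillation counting, with a stated time of 60 min, tested at 10 uM (on this read-out lower numbers stand for less inhibition and higher numbers for more inhibition at the one concentration tested (going by the name of the read-out)), compound 2, `N=c1oc2ccc(Br)cc2cc1C(=O)NCC(O)CO`, gives 11%, the lower of the two numbers recorded in this series. Its nearest neighbour is compound 3, `COc1cccc2cc(C(=O)NCC(=O)O)c(=O)oc12`, which gives 27%, a gap beyond the usual scatter. Compound 1, `COCCNC(=O)c1cc2cccc(OC)c2oc1=N`, reaches only a limit of the assay, > 70%; this is the one case covered by the limit of > 70% in this assay, at which 1 of the 3 values shown sits. Compound 4, `CCC(CO)NC(=O)c1cc2cc(Br)ccc2oc1=N`, is not yet measured. It differs from compound 2 in one place: 1-(hydroxymethyl)propyl in place of 2,3-dihydroxypropyl on an amide-type nitrogen. Within the data shown here, no measured pair shows this change, so no step size can be read from the data. The expectation is a modest rise, a number 14 percentage points higher from compound 2 to compound 4 (beyond the scatter), of a size that may or may not clear the scatter. Compound 4 is therefore estimated at 25%, with a range from 5% to 55%.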

Compound 4, a percentage reported as inhibition, at one concentration (the size of the read-out at that concentration, not a potency): 20%
Beside the measured number, compound 4's estimate is 5 percentage points above it; the range from low to high includes it.
By their numbers in this assay, from the lowest: compounds 2, 4 and 3 (each within the scatter of the next, the first and the last beyond it). At a limit, above all of these: compound 1.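

In this assay, 1-(hydroxymethyl)propyl in place of 2,3-dihydroxypropyl on the amide-type nitrogen gives a number 9 percentage points higher from compound 2 to compound 4 (within the scatter), the first step readable in this series. The entering group counts fewer hydrogen-bond donors and acceptors, yet the two compounds are not separated at this position. No measurement shown bears on the reason for this result.

Still open, going by these compounds, is whether an amine or a longer chain on that nitrogen would move the read-out beyond the scatter on the shared core. Compound 1 differs from both compounds in more than one place, so its limit cannot be tied to its chain.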